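A few compounds are considered here, and "the series" means these few. Any claim that something is new, unique, unknown or untested is made for them only; others in the source may bear on it.

Working notes on the series, read in an ADME assay on MT4 cells (Homo sapiens) for cytotoxicity, read by MTT assay, with a stated time of 5 days; on this read-out higher numbers stand for lower toxicity in this test and lower numbers for higher toxicity in this test.

Compound 1 `COc1cc2nc(SCC(=O)Nc3ccc(S(N)(=O)=O)cc3)nc(Nc3c(Cl)cc(/C=C/C#N)cc3Cl)c2cc1OC` carries a 4-sulfamoylphenyl on an amide-type nitrogen; in this assay compound 1 gives 116000 nM. Compound 2 `COc1cc2nc(SCC(=O)Nc3cc([N+](=O)[O-])ccc3F)nc(Nc3c(Cl)cc(/C=C/C#N)cc3Cl)c2cc1OC` differs from it by 2-fluoro-5-nitrophenyl in place of 4-sulfamoylphenyl on an amide-type nitrogen. In this assay compound 2 gives > 199000 nM, which is a limit of the assay and not a number. The measured step is an at least 1.7-fold higher number from compound 1 to compound 2 (0.23 log units; that floor lies within the scatter), its floor set by the limit of > 199000 nM in this assay, at which 1 of the 3 values shown sits.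

Compound 3 `COc1cc2nc([S+]([O-])CC(=O)Nc3ccc(S(N)(=O)=O)cc3)nc(Nc3c(Cl)cc(/C=C/C#N)cc3Cl)c2cc1OC` keeps the 4-sulfamoylphenyl of compound 1 on a core that differs from the core of compound 1; the difference between the two cores is not broken down here. In this assay compound 3 gives > 189000 nM, a limit of the assay and not a number. Compound 3 thus sits at the limit of > 189000 nM in this assay, at which 1 of the 3 values shown sits.

Compound 4 `COc1cc2nc([S+]([O-])CC(=O)Nc3cc([N+](=O)[O-])ccc3F)nc(Nc3c(Cl)cc(/C=C/C#N)cc3Cl)c2cc1OC` is not yet measured in this assay. It stands to compound 3 as compound 2 stands to compound 1: 2-fluoro-5-nitrophenyl in place of 4-sulfamoylphenyl on an amide-type nitrogen, the same change, on an amide-type nitrogen whose other neighbour is a carbonyl carbon in both pairs. The expectation for compound 4 rests on compound 3 sitting at the limit of > 189000 nM in this assay, at which 1 of the 3 values shown sits, and on the earlier step of an at least 1.7-fold higher number from compound 1 to compound 2 (0.23 log units; that floor lies within the scatter), which itself yielded only a floor. For compound 4 a step that the limit leaves unreadable from compound 3 to compound 4 is expected, and a reading that is again only a limit is held likely. In this assay compound 4 is expected to give 220000 nM, with a likely range from 110000 nM to 450000 nM.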

Compound 4, half-maximal cytotoxic concentration: > 194000 nM
Compound 4: no number, only a limit; the forecaster's own chance of this, stated with the estimate: 75%; the middle value does not contradict the limit.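

In this assay compound 3 is a limit and not a number: the limit of > 189000 nM in this assay, at which 1 of the 4 values shown sits. Compound 4 is also a limit and not a number: the limit of > 194000 nM in this assay, at which 1 of the 4 values shown sits. Going by these compounds alone, no step between compound 3 and compound 4 can be read. The compounds shown leave open the actual size of any difference between 4-sulfamoylphenyl and 2-fluoro-5-nitrophenyl on either core, and between the core of compound 1 and the core of compound 3.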